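Changing the Aryl Group of Compound 1

The source may report more compounds than this note shows. Statements on the series, on what has been measured and on what is new or still open speak of the compounds shown alone.

Measured so far:
- compound 1 `CC1=C(/C=C/C(=O)/C=C/c2ccc(Br)cc2)C(C)(C)CCC1` gives 34500 nM in a functional assay on Hep cells (Homo sapiens) for cytotoxicity, read by sulforhodamine B assay, with a stated time of 48 h; a lower number here means a stronger inhibitor, a higher number a weaker inhibitor
- compound 2 `CC1=C(/C=C/C(=O)/C=C/c2ccc([N+](=O)[O-])cc2)C(C)(C)CCC1` gives 55500 nM in this assay

Among the compounds with values here, compound 1 holds the lower of the two numbers, though the only measured step, a 1.6-fold higher number from compound 1 to compound 2 (0.21 log units; within the scatter), is within the scatter. Compound 3 `CC1=C(/C=C/C(=O)/C=C/c2ccccc2Cl)C(C)(C)CCC1` differs from compound 1 by 2-chlorophenyl in place of 4-bromophenyl on a double-bonded chain carbon bound to a double-bonded chain carbon. That earlier step also swapped one group on the same aromatic ring and barely moved the number, so no step beyond the scatter is expected here: the estimated change is a 1.2-fold higher number from compound 1 to compound 3 (0.06 log units; within the scatter). Compound 3 is therefore expected to give about 40000 nM in this assay, likely between 15000 nM and 110000 nM.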

Compound 3, half-maximal inhibitory concentration: 54200 nM
The estimate for compound 3 lay 1.4-fold (0.13 log units) below the measured number; the measured number falls inside the stated range.
By their numbers in this assay, from the lowest: compounds 1, 3 and 2 (each within the scatter of the next).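

Swapping 4-bromophenyl for 2-chlorophenyl changes the halogen and its numbered ring position together, and the outcome in this assay is a 1.6-fold higher number from compound 1 to compound 3 (0.20 log units; within the scatter). This place on the chain has now taken two different changes to the aryl group, in compound 2 and compound 3, with no step beyond the scatter. Nothing available here bears on why these numbers came out as they did.

All three compounds keep a substituted phenyl ring at this place. As far as these compounds go, whether a phenyl ring carrying an amine or a carboxylic acid would move the number beyond the scatter remains open.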